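This account rests on a few compounds, and the source may have more. Where it says the series, first, only, none or still open, it means among the compounds named here.

Among the compounds with values here, compound 3 `Cc1c(OC[C@@H](C)COc2ccc(C(=O)O)c(Cl)c2)ccc(C(=O)CC(C)(C)C)c1O` gives the smallest of the three numbers measured so far in an assay for positive allosteric modulation of metabotropic glutamate receptor 3 (Rattus norvegicus) (on this read-out higher numbers stand for an effect only at larger amounts of compound and lower numbers for an effect already at smaller amounts), namely 860 nM, while compound 2 `Cc1c(OC[C@@H](C)COc2ccc(C(=O)O)cc2F)ccc(C(=O)CC(C)(C)C)c1O` gives 1300 nM and compound 1 `Cc1cc(C(=O)O)ccc1OC[C@H](C)COc1ccc(C(=O)CC(C)(C)C)c(O)c1C` gives 1520 nM. The steps of a 1.8-fold lower number from compound 1 to compound 3 (0.25 log units; within the scatter) and a 1.5-fold lower number from compound 2 to compound 3 (0.18 log units; within the scatter) both stay within the scatter, as does a 1.2-fold lower number from compound 1 to compound 2 (0.07 log units; within the scatter), so no order among the three is claimed. Compound 4 `COc1cccc(OC[C@H](C)COc2ccc(C(=O)CC(C)(C)C)c(O)c2C)c1` differs from compound 3 by 3-methoxyphenyl in place of 4-carboxy-3-chlorophenyl on an oxygen on a saturated carbon. Within the data shown here, none of the measured steps covers this change: each kept the carboxy group and varied only the methyl, fluoro or chloro on that ring, and all were within the scatter. The expected size of the step in this assay is therefore uncertain, with a higher number thought somewhat more likely. Compound 4 is estimated at 2500 nM, in the range 700 nM to 9000 nM. This corresponds to an expected 2.9-fold higher number from compound 3 to compound 4 (0.46 log units; beyond the scatter).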

Compound 4, half-maximal effective concentration: "not active" (no number reported)
No number was reported for compound 4; the estimate stays without a comparison.
By their numbers in this assay, from the lowest: compounds 3, 2 and 1 (each within the scatter of the next).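

Within the data shown here, compound 4 was reported only as "not active" in this assay, so no step from compound 3 to compound 4 can be read, and no evidence bears on this result. The compounds shown leave open which part of the change from 4-carboxy-3-chlorophenyl to 3-methoxyphenyl matters.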